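Compound 3: 2-hydroxyethyl in place of 2-methoxyethyl

The compounds below may be only part of what the source reports. "The series", "measured", "known", "first", "only" and "open" are said of these compounds alone.

In an in vitro ADME assay on microsomes from liver (Homo sapiens) for metabolic stability, read by LC-MS, tested at 1 uM (a lower number here means that the compound disappears faster, a higher number that the compound lasts longer), compound 1 `CC(C)(C)c1ccc(NC(=O)Nc2ccc3[nH]ncc3c2)s1` gives 0.917 h. Compound 2 `COCCNC(=O)c1cc(C(C)(C)C)sc1NC(=O)Nc1ccc2[nH]ncc2c1` reads > 2 h, which is a limit of the assay and not a number. Going by the values given here, the one measured step, an at least 2.1-fold higher number from compound 1 to compound 2 (0.33 log units; beyond the scatter), is beyond the scatter and comes with (2-methoxyethyl)carbamoyl in place of hydrogen on an aromatic carbon. Compound 3 `CC(C)(C)c1cc(C(=O)NCCO)c(NC(=O)Nc2ccc3[nH]ncc3c2)s1` differs from compound 2 by hydrogen in place of methyl on an oxygen on a saturated carbon, that is, 2-methoxyethyl to 2-hydroxyethyl. The measured step introduces the whole side chain and does not test hydrogen in place of methyl on an oxygen, so it gives only indirect guidance. No clear change is therefore expected in this assay, and the expected step, a step that the limit leaves unreadable from compound 2 to compound 3, stays within the scatter. Compound 3 may likewise return only a limit, as with the limit of > 2 h in this assay, at which 1 of the 2 values shown sits. For compound 3 the estimated half-life is 2.2 h, with an expected range of 1.1 h to 4.4 h.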

Compound 3, half-life in the Homo sapiens assay: > 2 h
Compound 3 was reported as a limit; the forecaster's own chance of this, stated with the estimate: 55%; the middle value is on the limit's open side.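

In the Homo sapiens assay compound 3 reads > 2 h, which is a limit of the assay and not a number. The step from compound 2 to compound 3 cannot be read there. In the Homo sapiens assay, adding the side chain with its hydroxy end gives an at least 2.1-fold higher number from compound 1 to compound 3 (0.33 log units; beyond the scatter), so the free hydroxy end matches what was seen with the methoxy end only as far as the limit allows. In a physicochemical assay for solubility, in phosphate buffer, measured as kinetic solubility, at pH 6.5 (on this read-out higher numbers stand for higher solubility and lower numbers for lower solubility), compound 2 gives 10 ug/mL and compound 3 gives 41 ug/mL. The change does show up in the physicochemical assay, with a 4.1-fold higher number from compound 2 to compound 3 (0.61 log units; beyond the scatter).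

Going by these compounds, how compound 2 and compound 3 truly rank on half-life stays open: the limit of > 2 h in the Homo sapiens assay, at which 2 of the 3 values shown sit. Also open is whether an amine or a carboxylic acid at the end of the chain, or a longer chain, would keep the half-life and carry solubility further.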